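This account rests on a few compounds, and the source may have more. Where it says the series, first, only, none or still open, it means among the compounds named here.

Measured compounds:
Compound 1 `Cc1nc2c(COc3ccccc3)cccn2c1N`: in a functional assay on the whole organism with Canis familiaris (Canis lupus familiaris) as the target, at a dose of 5 mg/kg by the intravenous route (on this read-out higher numbers stand for a stronger effect at the one dose given and lower numbers for a weaker effect), compound 1 gives 34%.
Compound 2 `Cc1nc2c(OCc3ccccc3)cccn2c1CN`: in this assay compound 2 gives 49%.

Of the two numbers in hand, compound 2 holds the higher one; compound 1 sits lower by a margin that lies beyond the usual scatter of repeated runs of this assay. The two differ in more than one place, so their values can only be read side by side, not as a single step.

The next compound, compound 3 `Cc1nc2c(OCc3ccccc3)cccn2c1NC(C)C`, has not yet been tested in this assay. It departs from compound 2 in one place: isopropylamino in place of aminomethyl on an aromatic carbon. Going by the values given here, no pair in the data tells how much such a change shifts the read-out, and the second measured compound, compound 1, carries its own several differences, so nothing fixes the direction. Because compound 2 gives 49% and the change is contained, a modest step is the plainest expectation. The step expected is a number 9 percentage points lower from compound 2 to compound 3 (within the scatter), which may not clear the scatter. Compound 3 is estimated at 40%, within a range from 15% to 65%.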

Compound 3, a percentage reported as inhibition, in the whole organism at one dose (the size of the read-out at that dose, not a potency): 0%
The estimate for compound 3 lay 40 percentage points above the measured number; the measured number lies below the stated range.
By their numbers in this assay, from the lowest: compound 3; then compound 1; then compound 2.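

Exchanging aminomethyl for isopropylamino on this aromatic carbon of the five-membered ring gives a number 49 percentage points lower from compound 2 to compound 3 (beyond the scatter) in this assay and leaves compound 3 at 0% at the one dose given, so this single place can decide whether any effect is seen at all. The loss comes without a change in the counted features, as the two groups match in hydrogen-bond donors, hydrogen-bond acceptors and net charge, and neither brings a ring, while the entering group is larger by its added carbon. The data in hand offer no measurement that accounts for this drop.

On these data alone, what stays open is whether the loss follows the branched isopropyl part or the nitrogen sitting directly on the ring carbon, a question that groups such as methylamino, dimethylamino or aminoethyl at this place would help to separate. As far as these compounds go, it is also open how a carboxylic acid or a longer chain bearing an amine would behave here, and compound 1 cannot settle any of this, since it differs from the others in more than one place.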